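This account rests on a few compounds, and the source may have more. Where it says the series, first, only, none or still open, it means among the compounds named here.

Of the compounds shown here, two have been tested in a functional assay on KB cells (Homo sapiens) for inhibition; on this read-out higher numbers stand for weaker inhibition and lower numbers for stronger inhibition. Compound 1 `COc1ccc2c(C)cc(N/N=C/c3ccccc3O)nc2c1` gives 2000 nM, while compound 2 `COC(=O)c1[nH]c2cc(OC)ccc2c1C(=O)c1cc(OC)c(OC)c(OC)c1` gives 5.5 nM. Of the two, compound 2 has the lower number; the gap to compound 1 lies beyond the usual scatter, so compound 2 is the stronger inhibitor here.

The next compound, compound 3 `CCCc1[nH]c2cc(OC)ccc2c1C(=O)c1cc(OC)c(OC)c(OC)c1`, keeps the core of compound 2 and changes one group: propyl in place of methoxycarbonyl on an aromatic carbon. Going by the values given here, no measured pair in this set shows what such a swap does, so the expectation rests on compound 2 alone. Because compound 2 gives 5.5 nM, a modest weakening rather than a large one is expected, and the step in this assay is estimated as a 4.5-fold higher number from compound 2 to compound 3 (0.66 log units; beyond the scatter). For compound 3 the value in this assay is therefore expected to be about 25 nM, within a range from 5 nM to 150 nM.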

Compound 3, half-maximal inhibitory concentration: 11 nM
Estimate against measurement, compound 3: 2.3-fold (0.36 log units) above, and the stated range covers the measured number.
By their numbers in this assay, from the lowest: compounds 2 and 3 (each within the scatter of the next); then compound 1.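

In this assay the swap of methoxycarbonyl for propyl on this aromatic carbon, next to the ring nitrogen, gives a 2.0-fold higher number from compound 2 to compound 3 (0.30 log units; within the scatter) and so leaves the two compounds indistinguishable. The group that leaves has a double bond and hydrogen-bond acceptors, while the group that enters is made of carbon alone and has neither. For this pair, then, a low number at this position does not depend on those features of methoxycarbonyl, and an ester-type group can give way to a plain alkyl chain without a change beyond the scatter.

On these data alone, whether a longer chain, a carboxylic acid or an amine on the same carbon would also keep the number this low remains open. The measurements also offer no explanation for why this swap makes so little difference.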